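The compounds below may be only part of what the source reports. "The series", "measured", "known", "first", "only" and "open" are said of these compounds alone.

Measured compounds:
Compound 1, `Fc1cc2nc(-c3cccnc3)n(C3CC3)c2cc1F`, in an assay on V79 cells for inhibition of cytochrome P450 11B2, mitochondrial (Homo sapiens), read by HTRF, with a stated time of 1 h (on this read-out higher numbers stand for weaker inhibition and lower numbers for stronger inhibition), compound 1 gives 2.1 nM.
Compound 2, `Fc1ccc2nc(-c3cccnc3)n(C3CC3)c2c1`, in this assay compound 2 gives 4 nM.
Compound 3, `COc1ccc2nc(-c3cccnc3)n(C3CC3)c2c1`, in this assay compound 3 gives 24 nM.

Compound 2 stands second highest of the three numbers. Its nearest neighbour is compound 1, with a 1.9-fold higher number from compound 1 to compound 2 (0.28 log units; within the scatter), and its furthest is compound 3, with a 6.0-fold higher number from compound 2 to compound 3 (0.78 log units; beyond the scatter). The move from compound 2 to compound 4, `Fc1ccc2nc(-c3cccnc3)n(C3CCC3)c2c1`, is of a different kind: cyclobutyl in place of cyclopropyl on an aromatic nitrogen. The two measured steps both concern a group on an aromatic carbon of the shared core, one hydrogen for fluoro and one methoxy for fluoro, and neither touches the group on the aromatic nitrogen. So no measured step bears directly on the change from compound 2 to compound 4, and there is nothing in these three numbers that points to a step in either direction. The expectation for compound 4 is therefore a step within the scatter, with compound 2 as the anchor, which is what no change at the digits printed from compound 2 to compound 4 (within the scatter) expresses. On that basis compound 4 is estimated at 4 nM in this assay, with a range from 1.5 nM to 12 nM, and the measurement will show whether the ring size on the aromatic nitrogen matters here.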

Compound 4, half-maximal inhibitory concentration: > 5000 nM
Compound 4 was reported as a limit; the forecaster's own chance of this, stated with the estimate: 2%; at least 1200-fold (3.09 log units) between middle value and limit.
By their numbers in this assay, from the lowest: compounds 1 and 2 (each within the scatter of the next); then compound 3. At a limit, above all of these: compound 4.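

Compound 1, compound 2 and compound 3 all carry cyclopropyl on the aromatic nitrogen and differ only on an aromatic carbon of the shared core, so they showed nothing about how this position responds to change. Here, with the three-membered ring giving way to a four-membered ring, cyclobutyl in place of cyclopropyl gives an at least 1200-fold higher number from compound 2 to compound 4 (3.09 log units; beyond the scatter) in this assay, which shows that this position tolerates far less than the aromatic carbon does and makes this the largest step among the compounds shown. Compound 4 is reported only as a limit, not as a number: the limit of > 5000 nM in this assay, at which 1 of the 4 values shown sits.

As far as these compounds go, how an ethyl, an isopropyl or a cyclopentyl group on the aromatic nitrogen would read in this assay remains open, so these compounds do not settle whether the loss belongs to cyclobutyl alone or extends to other groups at this position. Also open, from the compounds shown here alone, is whether the same change would give a similar step with the fluoro groups of compound 1 or the methoxy group of compound 3 on the core, or with an amine on the aromatic carbon.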